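Acylation of the aniline nitrogen in the shared core

The source may hold more compounds than are shown below. What is called first, only, known or untested is meant among the compounds shown, and "the series" means these compounds.

Measured so far in a functional assay on L1210 cells (Mus musculus) for inhibition, read by cell counting, with a stated time of 2 days; a lower number here means a stronger inhibitor, a higher number a weaker inhibitor:
- compound 1 `COc1ccc(Cc2nn3cc(-c4cccc(N)c4)nc3s2)cc1`: compound 1 gives 227000 nM
- compound 2 `Nc1cccc(-c2cn3c(-c4ccc(Cl)cc4)csc3n2)c1`: compound 2 gives 22000 nM
- compound 3 `Nc1cccc(-c2cn3c(-c4ccccc4)csc3n2)c1`: compound 3 gives 85000 nM

Compound 3 stands second highest of the three numbers in this assay; compound 1 lies above it and compound 2 below it, both gaps beyond the scatter. Among the compounds with values here, the only step between single-point neighbours, a 3.9-fold higher number from compound 2 to compound 3 (0.59 log units; beyond the scatter), concerns a substituent on the pendant phenyl ring and not the aniline nitrogen.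

Compound 4 `C=C(Br)C(=O)Nc1cccc(-c2cn3c(-c4ccccc4)csc3n2)c1` differs from compound 3 by (1-bromoethenyl)carbonyl in place of hydrogen on a nitrogen on an aromatic ring. Within the data shown here, no measured step bears on acylation of this nitrogen, so its direction in this assay is open; a step of moderate size in either direction is expected. Compound 4 is estimated at 40000 nM, range 6000 nM to 250000 nM, meaning an expected step of a 2.1-fold lower number from compound 3 to compound 4 (0.33 log units; beyond the scatter).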

Compound 4, half-maximal inhibitory concentration: 1300 nM
Beside the measured number, compound 4's estimate is 31-fold (1.49 log units) above it; the whole stated range lies above it.
By their numbers in this assay, from the lowest: compound 4; then compound 2; then compound 3; then compound 1.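

In this assay, within the data shown here, (1-bromoethenyl)carbonyl in place of hydrogen on the aniline nitrogen gives a 65-fold lower number from compound 3 to compound 4 (1.82 log units; beyond the scatter), the first reading at this position. The free amino group of compound 3 is therefore not required for inhibition in this assay, and acylation here can lower the number substantially. No available evidence explains the size of this step.

The compounds shown do not separate the contributions of the bromine, the carbon-carbon double bond and the carbonyl; a plain acetyl or an unsubstituted acryloyl group would address this. Going by these compounds, whether the step carries over to compound 2 also remains open.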